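The compounds below may be only part of what the source reports. "The series", "measured", "known", "first", "only" and "open" are said of these compounds alone.

Measured in a functional assay on CCRF-CEM cells (Homo sapiens) for antiproliferative activity, read by cell counting, with a stated time of 2 days; on this read-out higher numbers stand for weaker inhibition and lower numbers for stronger inhibition:

- Compound 1 `COc1cc(C(=O)c2sc(Nc3ccc(F)cc3)nc2N)cc(OC)c1OC`: 400 nM
- Compound 2 `Nc1nc(Nc2ccc(Cl)cc2)sc1C(=O)c1ccccc1`: > 10000 nM
- Compound 3 `COc1ccccc1C(=O)c1sc(Nc2ccccc2)nc1N`: 730 nM

Compound 1 gives 400 nM and compound 3 gives 730 nM, two numbers that lie within the usual scatter of each other. The entry for compound 2 is a limit of the assay and not a number.

The next compound to consider is compound 4 `COc1ccc(Nc2nc(N)c(C(=O)c3cc(OC)c(OC)c(OC)c3)s2)cc1`. It keeps the rest of compound 1 but has methoxy in place of fluoro on an aromatic carbon, para to a large group, so that 4-fluorophenyl becomes 4-methoxyphenyl (methoxy in place of fluoro on an aromatic carbon).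

For the measured compounds named here, no two measured compounds differ in one place only, so the data give no direct measure of what this kind of change does. Compound 1 at 400 nM is the closest reference point, and the expectation in this assay is for little or no step beyond the scatter, with no firm direction. The range is kept wide to reflect this lack of direct evidence.

The expected step is a 1.1-fold lower number from compound 1 to compound 4 (0.06 log units; within the scatter). For compound 4 the estimate is 350 nM, with an expected range from 100 nM to 1500 nM.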

Compound 4, half-maximal inhibitory concentration: 1100 nM
Compound 4: the middle estimate sits 3.1-fold (0.50 log units) below what was measured; the range from low to high includes it.
By their numbers in this assay, from the lowest: compounds 1, 3 and 4 (each within the scatter of the next, the first and the last beyond it). At a limit, above all of these: compound 2.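

In this assay, placing methoxy in place of fluoro on an aromatic carbon, para to a large group, gives a 2.8-fold higher number from compound 1 to compound 4 (0.44 log units; beyond the scatter). This is the only comparison shown in which a single place changes while the rest of the molecule stays the same, and it shows that this position is not indifferent: the change from 4-fluorophenyl to 4-methoxyphenyl weakens inhibition by a modest but readable amount. Nothing measured here bears on what lies behind this step.

On these data alone, one step between two groups gives no trend, so it remains open how other groups on this aromatic carbon would compare with fluoro and methoxy, for example a hydroxyl, an amine, a carboxylic acid or a longer chain such as ethoxy. Compound 2 and compound 3 each differ from compound 1 and compound 4 in more than one place, so they cannot show whether the same change would have a similar effect with a different group on the other side of the core.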